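The compounds below may be only part of what the source reports. "The series", "measured", "known", "first", "only" and "open" are said of these compounds alone.

Measured so far in a functional assay on RPMI-8226 cells (Homo sapiens) for inhibition, read by sulforhodamine B assay, with a stated time of 48 h, tested at 10 uM; on this read-out higher numbers stand for a weaker effect at the one concentration tested and lower numbers for a stronger effect:

- compound 1, `COc1cc2cc(Oc3ccc(NC(=O)Nc4ccc(C)cc4)cc3)c(C)nc2cc1OC`, gives 101%
- compound 2, `COc1cc2cc(Oc3ccc(NC(=O)Nc4ccc(C(F)(F)F)cc4)cc3)c(C)nc2cc1OC`, gives 52.7%
- compound 3, `COc1cc2cc(Oc3ccc(NC(=O)Nc4cccc(C(F)(F)F)c4)cc3)c(C)nc2cc1OC`, gives -5.94%

All three share one core and differ only in the aryl group on the urea-type nitrogen. Compound 3 stands at the strongest end: its number is the lowest of the three, and both of its steps lie beyond the scatter, a number 58.6 percentage points lower from compound 2 to compound 3 (beyond the scatter) and a number 106.9 percentage points lower from compound 1 to compound 3 (beyond the scatter). The other measured step, a number 48.3 percentage points lower from compound 1 to compound 2 (beyond the scatter), is also large.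

Compound 4, `COc1cc2cc(Oc3ccc(NC(=O)Nc4ccc(Cl)c(Cl)c4)cc3)c(C)nc2cc1OC`, has not yet been measured in this assay. It differs from compound 3 by 3,4-dichlorophenyl in place of 3-(trifluoromethyl)phenyl on an amide-type nitrogen.

For the measured compounds named here, none of the measured steps bears directly on this change: one exchanges trifluoromethyl for methyl, the other moves trifluoromethyl from one position to another, and no step involves chlorine at all. The three numbers only show that this part of the molecule can swing the read-out strongly in either direction. With no closer guide, compound 4 is expected to stay near compound 3, with an estimated step of a number 20.9 percentage points higher from compound 3 to compound 4 (beyond the scatter), and a wide range. The estimate for compound 4 is 15%, between -15% and 55%.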

Compound 4, a percentage reported as activity, at one concentration (the size of the read-out at that concentration, not a potency): 4.2%
Compound 4: the middle estimate sits 10.8 percentage points above what was measured; low and high end bracket the measured number.
By their numbers in this assay, from the lowest: compound 3; then compound 4; then compound 2; then compound 1.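

In this assay, the change to 3,4-dichlorophenyl on the amide-type nitrogen leaves compound 4 close to the strong end of the series, with a number 10.1 percentage points higher from compound 3 to compound 4 (beyond the scatter) as a modest step that still leaves compound 3 with the lowest number. The steps from the two weaker compounds are far larger, with a number 48.5 percentage points lower from compound 2 to compound 4 (beyond the scatter) and a number 96.8 percentage points lower from compound 1 to compound 4 (beyond the scatter), so a strong effect at this position does not depend on trifluoromethyl: 3-(trifluoromethyl)phenyl and 3,4-dichlorophenyl give the two lowest of the four numbers. Nothing available here explains why these two groups behave alike or why compound 3 keeps a small edge.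

From the compounds shown here alone, what a single chlorine on this ring would do remains open, as does which of the two chlorine atoms matters more for the read-out. It is also unknown whether a different kind of group on this ring, such as an amine or a carboxylic acid, would keep the number this low at the one concentration tested in this assay.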